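The source may report more compounds than this note shows. Statements on the series, on what has been measured and on what is new or still open speak of the compounds shown alone.

Measured compounds:
- compound 1 `Cn1c(Cc2nn(C)c(=O)c3ccccc23)nnc1SCCCCCC(=O)Nc1ccc(Cl)cc1Cl`: 4100 nM
- compound 2 `Cn1c(Cc2nn(C)c(=O)c3ccccc23)nnc1SCC(=O)Nc1ccc(Cl)cc1Cl`: 17300 nM
- compound 3 `Cn1c(Cc2nn(C)c(=O)c3ccccc23)nnc1S(=O)(=O)CCCCCCCC(=O)Nc1ccc(Br)cc1Br`: 1400 nM

All three were tested in an assay on isolated protein (Mus musculus) for inhibition of IL15-IL15 receptor (Homo sapiens), read by resazurin assay, with stated times of 30 min and 2.5 days; a lower number here means a stronger inhibitor, a higher number a weaker inhibitor. Among the three numbers compound 1 stands second highest: compound 3 sits at the lower number, separated from compound 1 by a gap beyond the scatter, and compound 2 sits at the higher number, also beyond the scatter from compound 1. Going by the values given here, the three compounds share the same core and differ in the chain carried on the sulfur, in the oxidation of that sulfur and in the halogens on the aryl ring; no single-point step between them is available, so only the bare values can be compared.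

The next compound, compound 4 `CCCCCCCCCCSc1nnc(Cc2nn(C)c(=O)c3ccccc23)n1C`, is reached from compound 1 by one change: pentyl in place of (2,4-dichlorophenyl)carbamoyl on a saturated chain carbon, five bonds along the chain from a sulfur. The chain keeps its length but the aryl amide at its end is gone, leaving a plain alkyl tail on the sulfur.

Among the compounds with values here, no measured pair shows this change, so its size in this assay is unknown. The removal of the hydrogen-bond donor and acceptor together with the aromatic ring is expected to weaken inhibition, a step of a 3.7-fold higher number from compound 1 to compound 4 (0.56 log units; beyond the scatter) beyond the scatter. Compound 4 is therefore expected to give about 15000 nM, within 4000 nM to 60000 nM.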

Compound 4, half-maximal inhibitory concentration: 7600 nM
Beside the measured number, compound 4's estimate is 2.0-fold (0.30 log units) above it; measured number inside the range.
By their numbers in this assay, from the lowest: compound 3; then compounds 1 and 4 (each within the scatter of the next); then compound 2.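

In this assay, going by these compounds alone, pentyl in place of (2,4-dichlorophenyl)carbamoyl on a saturated chain carbon, five bonds along the chain from a sulfur, gives a 1.9-fold higher number from compound 1 to compound 4 (0.27 log units; within the scatter) and provides the first comparison that differs in one place. For this pair, the inhibition read-out does not depend on the aryl amide end: the pentyl end of compound 4, with no ring, hydrogen-bond donor or hydrogen-bond acceptor, cannot be told apart from the end of compound 1 in this assay. Nothing in the data shown accounts for why these two ends read alike.

Still open, on these data alone, is whether a shorter or longer alkyl tail on the sulfur, or a carboxylic acid or an amine at the chain end, would keep the number within the scatter of compound 4. The separate contribution of a sulfone also remains unread, as compound 3 differs from compound 1 in more than one place.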